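Swapping a Chloro Group for a Trifluoromethyl Group

The source may hold more compounds than are shown below. What is called first, only, known or untested is meant among the compounds shown, and "the series" means these compounds.

Of the compounds shown here, two built on a shared core have been tested in a functional assay on HCT-15 cells (Homo sapiens) for inhibition, read by sulforhodamine B assay, with a stated time of 48 h, tested at 10 uM; a higher number here means more inhibition at the concentration tested (going by the name of the read-out), a lower number less inhibition. Compound 1 `O=Cc1ccc(-c2cn3ccnc3c(-c3ccc4ncn(C5CCCCC5)c4c3)n2)cc1` gives 49.1%. Among the compounds with values here, compound 2 `Clc1ccc(-c2cn3ccnc3c(-c3ccc4ncn(C5CCCCC5)c4c3)n2)cc1` gives 15.5%, the lower of the two numbers; the one measured step, a number 33.6 percentage points lower from compound 1 to compound 2 (beyond the scatter), came from chloro in place of formyl on an aromatic carbon. Compound 3 `FC(F)(F)c1cccc(-c2cn3ccnc3c(-c3ccc4ncn(C5CCCCC5)c4c3)n2)c1` differs from compound 2 in a single place: 3-(trifluoromethyl)phenyl in place of 4-chlorophenyl on an aromatic carbon. Within the data shown here, no measured step covers this particular exchange: the step from compound 1 to compound 2 replaced a formyl group, not a chloro group, so it offers only a loose guide, and nothing in the data points to a strong shift. The expected step is therefore a number 4.5 percentage points higher from compound 2 to compound 3 (within the scatter), no larger than the scatter. For compound 3 the estimate in this assay is 20%, with a range from 5% to 45%.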

Compound 3, a percentage reported as inhibition, at one concentration (the size of the read-out at that concentration, not a potency): 0.36%
Compound 3: the middle estimate sits 19.6 percentage points above what was measured, and the stated range ends above it.
By their numbers in this assay, from the lowest: compound 3; then compound 2; then compound 1.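

In this assay, the exchange of 4-chlorophenyl for 3-(trifluoromethyl)phenyl gives a number 15.1 percentage points lower from compound 2 to compound 3 (beyond the scatter), so a substituted phenyl group at this aromatic carbon of the shared core can lose inhibition even when the starting number is already low. Set against the formyl compound, the exchange of 4-formylphenyl for 3-(trifluoromethyl)phenyl gives a number 48.7 percentage points lower from compound 1 to compound 3 (beyond the scatter), which leaves compound 1 highest of the three, with its steps to both others beyond the scatter. Nothing available explains why these numbers fall.

The step from compound 2 to compound 3 changes both the group and where it sits on the phenyl ring, so these compounds cannot separate those two changes. Also open, on these data alone, is whether an amine or a carboxylic acid in place of the formyl group would keep the inhibition seen with compound 1.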